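The compounds below may be only part of what the source reports. "The series", "measured", "known", "first", "only" and "open" are said of these compounds alone.

Two compounds were measured in a functional assay on Right cardiac atrium for agonist activity at histamine H2 receptor (Cavia porcellus), with a stated time of 30 min, in the presence of a further agent that is not named here; a lower number here means a smaller maximal response, a higher number a larger maximal response:
compound 1 `COc1ccc(C(C)NC(=O)/N=C(\N)NCCCc2sc(N)nc2C)cc1` gives 0.91
compound 2 `Cc1nc(N)sc1CCCN/C(N)=N/C(=O)N[C@H](C)c1ccccc1` gives 0.95

In this assay compound 1 and compound 2 lie within the scatter of each other, both close to the full response of the reference agonist. Compound 3 `Cc1nc(N)sc1CCCN/C(N)=N/C(=O)NC(C)c1ccc(Cl)cc1` differs from compound 1 in one place: chloro in place of methoxy on an aromatic carbon. Within the data shown here, no measured pair shows this kind of change, so there is no direct guide. With both measured compounds near the top of the scale, compound 3 is expected to stay there as well. Compound 3 is estimated at 0.92, between 0.8 and 1, so the expected step a number 0.010 higher from compound 1 to compound 3 (within the scatter) lies within the scatter.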

Compound 3, intrinsic activity: the largest response reached, as a fraction of the reference agonist's: 0.93
The estimate for compound 3 lay 0.010 below the measured number, and the stated range covers the measured number.
By their numbers in this assay, from the lowest: compounds 1, 3 and 2 (each within the scatter of the next).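

Among these compounds, this is the first measured pair that differs in one place. On the aromatic carbon para to a large group, chloro in place of methoxy gives a number 0.020 higher from compound 1 to compound 3 (within the scatter) in this assay. The maximal response therefore stays close to that of the reference agonist with either group, although chloro brings one heavy atom and no hydrogen-bond acceptor, and no measurement here accounts for this.

Both groups carry no net charge, so the compounds shown leave open how an amine or a carboxylic acid would behave at this position.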